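Amide series: pyrimidin-4-yl in place of 2,5-dimethylphenyl

The compounds below may be only part of what the source reports. "The series", "measured", "known", "first", "only" and "open" are said of these compounds alone.

The series shares the core of compound 1 `COc1ccc2nc(C)cc(OCCNc3cc(C)cc(C)c3)c2c1`, which in a toxicity assay on HepG2 cells (Homo sapiens) for inhibition, read by CellTiter-Glo, with a stated time of 48 h (a higher number here means a weaker inhibitor, a lower number a stronger inhibitor), gives 31600 nM. Compound 2 `COc1ccc2nc(C)cc(OCC(=O)Nc3cc(C)ccc3C)c2c1` carries the amide bearing the 2,5-dimethylphenyl group, and in this assay compound 2 reaches only the limit > 100000 nM, with no number beneath it. Compound 3 `COc1ccc2nc(C)cc(OCC(=O)Nc3cc(OC)c(OC)c(OC)c3)c2c1` likewise returns only the limit > 100000 nM. Compound 2 thus stands at the limit of > 100000 nM in this assay, at which 2 of the 3 values shown sit, and only compound 1 yields a measured figure. Among the compounds with values here, no single-change step between measured compounds is available. Compound 4 `COc1ccc2nc(C)cc(OCC(=O)Nc3ccncn3)c2c1` differs from compound 2 by pyrimidin-4-yl in place of 2,5-dimethylphenyl on an amide-type nitrogen. Given that both amides measured sit at the limit of > 100000 nM in this assay, at which 2 of the 3 values shown sit, the expected step of a number no higher from compound 2 to compound 4 (the limit leaves the size open) is none beyond the usual scatter. Compound 4 is therefore estimated in this assay near 100000 nM, within 40000 nM to 300000 nM, most likely again reported only as a limit.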

Compound 4, half-maximal inhibitory concentration: > 100000 nM
Compound 4: a limit, no number (the forecaster's own chance of this, stated with the estimate: 75%); the middle value lies on the limit itself.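

Compound 2 and compound 4 both return only limits in this assay, and the step between them cannot be read. As far as these compounds go, whether pyrimidin-4-yl in place of 2,5-dimethylphenyl on an amide-type nitrogen shifts the value at all remains open.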